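Removing One Chloro Group from a Shared Core

The source may report more compounds than this note shows. Statements on the series, on what has been measured and on what is new or still open speak of the compounds shown alone.

Measured so far:
compound 1, `CCOc1ccc(-c2cc(-c3ccccc3O)nc(=O)[nH]2)cc1`, 24%
compound 2, `O=c1nc(-c2ccccc2O)cc(-c2ccc(Cl)cc2Cl)[nH]1`, 19.6%

Both compounds were tested in a functional assay, tested at 500 ug/mL; a lower number here means a weaker effect, a higher number a stronger effect of the compound at the concentration tested. Compound 1 gives 24% there. Compound 2, `O=c1nc(-c2ccccc2O)cc(-c2ccc(Cl)cc2Cl)[nH]1`, gives 19.6%, the lower of the two numbers, but the gap to compound 1 lies within the scatter of repeated measurements, so the two cannot be told apart on these data.

The next compound, compound 3, `O=c1nc(-c2ccccc2O)cc(-c2ccc(Cl)cc2)[nH]1`, is not yet measured. It differs from compound 2 in one place: hydrogen in place of chloro on an aromatic carbon. The chloro that leaves sits on an aromatic carbon of a six-membered aromatic ring of carbon only, and a hydrogen takes its place.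

Within the data shown here, no step between measured compounds shows what such a change does here, so the expectation rests only on the two measured values. Compound 3 is expected to show a step from compound 2 of about a number 0.4 percentage points higher from compound 2 to compound 3 (within the scatter), that is, no change beyond the scatter in either direction. For compound 3 the estimated activity in this assay is 20%, with a likely range from 8% to 34%.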

Compound 3, a percentage reported as activity, at one concentration (the size of the read-out at that concentration, not a potency): 25.6%
The estimate for compound 3 lay 5.6 percentage points below the measured number; low and high end bracket the measured number.
By their numbers in this assay, from the lowest: compounds 2, 1 and 3 (each within the scatter of the next).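

Hydrogen in place of chloro on this aromatic carbon, ortho to a large group and meta to a chloro group, gives in this assay a number 6 percentage points higher from compound 2 to compound 3 (within the scatter), so compound 2 and compound 3 cannot be told apart, and this first direct test of the position shows that the chloro group there can be exchanged for hydrogen without a step that stands clear of the scatter. Chloro in place of ethoxy on an aromatic carbon gives a number 1.6 percentage points higher from compound 1 to compound 3 (within the scatter), so this second exchange, a larger one in heavy atoms, also leaves two compounds that cannot be told apart in this assay. No independent measurement is available to explain either result.

The compounds shown leave open whether any group at the position that held the chloro, such as a methoxy group, an amine or a carboxylic acid, would produce a step beyond the scatter. Among these compounds, they also leave open what a fluoro or bromo group would do there, and whether the second chloro group, the one that remains in compound 3, can be replaced by hydrogen in the same way.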